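A few compounds are considered here, and "the series" means these few. Any claim that something is new, unique, unknown or untested is made for them only; others in the source may bear on it.

Measured so far in a functional assay on the whole organism (strain albino) for inhibition, with Rattus norvegicus as the target, read by paw edema, with stated times of 1 h and 3 h, at a dose of 100 umol/kg by the oral route; on this read-out lower numbers stand for less inhibition and higher numbers for more inhibition at the one dose given (going by the name of the read-out):
compound 1 `Cc1c(C(=O)N/N=C/c2ccc(N(C)C)cc2)no[n+]1[O-]`: 19%
compound 2 `Cc1c(C(=O)N/N=C/c2ccc([N+](=O)[O-])o2)no[n+]1[O-]`: 14%

Compound 1 and compound 2 lie within the usual scatter of each other, so compound 1 is not set apart on the numbers shown. Compound 3 `Cc1c(C(=O)N/N=C/c2ccc(Br)cc2)no[n+]1[O-]` differs from compound 1 by bromo in place of dimethylamino on an aromatic carbon. Within the data shown here, no step between measured compounds is available for this change; with both measured numbers low and close, no step beyond the scatter is expected, and the estimated step of a number 3 percentage points lower from compound 1 to compound 3 (within the scatter) is taken as flat. Compound 3 is therefore expected to give about 16%, within a range from 4% to 30%.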

Compound 3, a percentage reported as inhibition, in the whole organism at one dose (the size of the read-out at that dose, not a potency): 0%
For compound 3 the middle estimate is 16 percentage points above the measured one; the whole stated range lies above it.
By their numbers in this assay, from the lowest: compound 3; then compounds 2 and 1 (each within the scatter of the next).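

Bromo in place of dimethylamino on an aromatic carbon, para to a large group, gives a number 19 percentage points lower from compound 1 to compound 3 (beyond the scatter) in this assay. This position on the six-membered aromatic ring therefore responds to the group it carries, which the earlier pair, differing in more than one place, could not show. Nothing at hand accounts for this step.

On these data alone, whether the drop follows the loss of dimethylamino or the arrival of bromo stays open. An amino group, methoxy or a carboxylic acid at the same place would help separate the two.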